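Replacing the Side Chain of Compound 3

This account rests on a few compounds, and the source may have more. Where it says the series, first, only, none or still open, it means among the compounds named here.

Three related compounds have been examined in a toxicity assay on C8166 cells (Homo sapiens) for cytotoxicity, read by MTT assay, with a stated time of 72 h; on this read-out higher numbers stand for lower toxicity in this test and lower numbers for higher toxicity in this test. Compound 1 `CS(=O)(=O)Oc1c(C(=O)NCc2ccc(F)cc2)nc(Br)c2cccnc12` gives 48000 nM. Compound 2 `NCCCNc1c(C(=O)NCc2ccc(F)cc2)nc(Br)c2cccnc12` has the entry "not determined" (no result reported), so it offers no number for comparison. Compound 3 `C[C@@H](CO)Nc1nc(C(=O)NCc2ccc(F)cc2)c(O)c2ncccc12` gives 107000 nM, the higher of the two available numbers, and its gap to compound 1 lies beyond the usual scatter of repeated measurements.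

Compound 4 `O=CNCCCCCCNc1nc(C(=O)NCc2ccc(F)cc2)c(O)c2ncccc12` differs from compound 3 in one place: 6-(formylamino)hexyl in place of 1-(hydroxymethyl)ethyl on a nitrogen on an aromatic ring. Here, 6-(formylamino)hexyl takes the place of 1-(hydroxymethyl)ethyl on a nitrogen on an aromatic ring. Among the compounds with values here, no measured pair of compounds shows this change on its own, so the expectation is only a rough one. With compound 3 at 107000 nM and compound 1 lower at 48000 nM, a fall seems more likely than a rise. A moderate step to a lower number, meaning higher toxicity and lying beyond the scatter, is expected: a 2.4-fold lower number from compound 3 to compound 4 (0.38 log units; beyond the scatter). For compound 4 the estimate is 45000 nM, with an expected range from 15000 nM to 130000 nM.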

Compound 4, half-maximal cytotoxic concentration: 199000 nM
For compound 4 the middle estimate is 4.4-fold (0.65 log units) below the measured one, and the stated range ends below it.
By their numbers in this assay, from the lowest: compound 1; then compounds 3 and 4 (each within the scatter of the next).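

On a nitrogen on an aromatic ring, 6-(formylamino)hexyl can replace 1-(hydroxymethyl)ethyl with a 1.9-fold higher number from compound 3 to compound 4 (0.27 log units; within the scatter) in this assay, so this read-out does not separate the two compounds. The entering group has 9 heavy atoms against 4 in the group that leaves and has no defined stereocentre, yet these differences in size and stereocentre come with no shift beyond the scatter. The compounds shown offer no measured evidence on the reason for this result.

On these data alone, it remains open whether a chain carrying an amine or a carboxylic acid in place of the formylamino group, or a longer chain, would read the same. One step cannot establish a trend with chain size, so compound 3 and compound 4 alone give no rule for this position.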